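Bromine on the Core: Projecting Compound 3 from Compound 1

The compounds below may be only part of what the source reports. "The series", "measured", "known", "first", "only" and "open" are said of these compounds alone.

Measured so far:
compound 1 `O=C(NS(=O)(=O)c1ccccc1)n1ccc2cccnc21`, 4500 nM
compound 2 `O=C(NS(=O)(=O)c1cccc([N+](=O)[O-])c1)n1ccc2cccnc21`, 800 nM

Of the compounds shown here, two sharing one core have been tested in an assay on COS7 cells for inhibition of Ectonucleotide pyrophosphatase/phosphodiesterase family member 1 (Homo sapiens), with a stated time of 35 min; a lower number here means a stronger inhibitor, a higher number a weaker inhibitor. Compound 1 gives 4500 nM, the highest of the two numbers; its nearest neighbour is compound 2, and the change from compound 1 to compound 2 is a 5.6-fold lower number from compound 1 to compound 2 (0.75 log units; beyond the scatter), a modest effect that lies beyond the scatter and comes from a nitro in place of hydrogen on the sulfonyl-bearing phenyl.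

Compound 3 `O=C(NS(=O)(=O)c1ccccc1)n1ccc2cc(Br)cnc21` is not yet measured. It differs from compound 1 by bromo in place of hydrogen on an aromatic carbon. Within the data shown here, this change sits on the core rather than on the phenyl ring, so the only measured step, from compound 1 to compound 2, touches a different part of the molecule and bears on it only loosely. Among the measured compounds shown here, with no closer precedent, a small change in this assay, in either direction, is expected, most likely within or just beyond the scatter and tending toward a slightly lower number, as in compound 2 with its 800 nM.

For compound 3 the estimate is 3000 nM, with a range from 1000 nM to 9000 nM, that is an expected step of a 1.5-fold lower number from compound 1 to compound 3 (0.18 log units; within the scatter).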

Compound 3, half-maximal inhibitory concentration: 8300 nM
Compound 3: the middle estimate sits 2.8-fold (0.44 log units) below what was measured; low and high end bracket the measured number.
By their numbers in this assay, from the lowest: compound 2; then compounds 1 and 3 (each within the scatter of the next).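

In this assay, bromo in place of hydrogen on an aromatic carbon of the six-membered aromatic ring with 1 nitrogen gives a 1.8-fold higher number from compound 1 to compound 3 (0.27 log units; within the scatter) and so leaves compound 1 and compound 3 indistinguishable in this measurement. Among these compounds, this is the first reading from the core itself, and it shows that this carbon, two atoms from the ring nitrogen, can carry a single bromine atom with no change that can be separated from the scatter, whereas the only earlier step, a 5.6-fold lower number from compound 1 to compound 2 (0.75 log units; beyond the scatter), came from a nitro on the phenyl ring and lay beyond it. Nothing given here accounts for the size of the bromo step, as no supporting evidence bears on it.

The compounds shown leave open whether any other group on this carbon, such as an amine, a carboxylic acid or a longer chain, would move the number beyond the scatter in either direction. They also leave open whether bromo on the core, combined with nitro on the phenyl ring, would give a number close to that of the nitro change alone.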